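Benzoxazole amine series: methylamino replacing 4-fluorophenylamino

The source may report more compounds than this note shows. Statements on the series, on what has been measured and on what is new or still open speak of the compounds shown alone.

Compound 1 `c1cnc2ccc(-c3ccc4oc(NC5CCCCC5)nc4c3)cc2c1` stops at a limit in an assay on HEK293 cells for inhibition of Fatty-acid amide hydrolase 1 (Homo sapiens), read by fluorescence (on this read-out lower numbers stand for stronger inhibition and higher numbers for weaker inhibition), giving > 1000 nM, which is a limit of the assay (the limit of > 1000 nM in this assay, at which 1 of the 2 values shown sits). For the measured compounds named here, compound 2 `Cn1ccc2cc(-c3ccc4oc(Nc5ccc(F)cc5)nc4c3)ccc21` gives 99 nM in this assay, the only numeric value in the set. Compound 3 `CNc1nc2cc(-c3ccc4c(ccn4C)c3)ccc2o1` is not yet measured; it differs from compound 2 by methyl in place of 4-fluorophenyl on a nitrogen on an aromatic ring. Without a measured step of this kind, the expected move is a loss beyond the scatter, estimated as a 12-fold higher number from compound 2 to compound 3 (1.08 log units; beyond the scatter). Compound 3 is expected to give about 1200 nM in this assay, with a likely range from 250 nM to 6000 nM.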

Compound 3, half-maximal inhibitory concentration: > 1000 nM
Compound 3 was reported as a limit (the forecaster's own chance of this, stated with the estimate: 50%); the middle value is on the limit's open side.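

With methyl in place of 4-fluorophenyl on a nitrogen on an aromatic ring, the series now has its first measured step, read in this assay as an at least 10-fold higher number from compound 2 to compound 3 (1.00 log units; beyond the scatter). At this position, 4-fluorophenyl cannot be reduced to methyl without a loss beyond the scatter. Compound 3 gives > 1000 nM, which is a limit, so only the minimum size of the step can be read: the limit of > 1000 nM in this assay, at which 2 of the 3 values shown sit.

Still open, as far as these compounds go, is whether an unsubstituted phenyl or a benzyl on this nitrogen would stay close to compound 2. Also open, from the compounds shown here alone, is whether the fluorine contributes at all.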